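Swapping a Phenyl for a Methoxy Group

The source may report more compounds than this note shows. Statements on the series, on what has been measured and on what is new or still open speak of the compounds shown alone.

Compound 3 `O=S(=O)(NCCCNCc1ccc(-c2ccccc2)cc1)c1cc(C(F)(F)F)cc(C(F)(F)F)c1` gives 2400 nM in a functional assay on MIA PaCa-2 cells (Homo sapiens) for inhibition, read by MTT assay, with a stated time of 72 h (a lower number here means a stronger inhibitor of growth, a higher number a weaker inhibitor of growth), the lowest of the three numbers shown. Compound 2 `O=S(=O)(NCCCNCC1COc2ccccc2O1)c1cc(C(F)(F)F)cc(C(F)(F)F)c1` gives 2600 nM and compound 1 `O=S(=O)(NCCCNCc1cccc(Cl)c1)c1cc(C(F)(F)F)cc(C(F)(F)F)c1` gives 4400 nM; both sit within the scatter of compound 3, so no ordering among the three can be claimed. Going by the values given here, the only measured step between neighbours, a 1.7-fold lower number from compound 1 to compound 2 (0.23 log units; within the scatter), alters the group on the saturated chain carbon and does not touch the aromatic ring changed here. Compound 4 `COc1ccc(CNCCCNS(=O)(=O)c2cc(C(F)(F)F)cc(C(F)(F)F)c2)cc1` differs from compound 3 by methoxy in place of phenyl on an aromatic carbon. Among the compounds with values here, no measured step of this kind exists, and all three numbers lie close together. Compound 4 is therefore expected to show a 1.5-fold higher number from compound 3 to compound 4 (0.16 log units; within the scatter), nothing beyond the scatter. Compound 4 is estimated at 3500 nM, with a likely range from 1500 nM to 8000 nM.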

Compound 4, concentration for 50% growth inhibition: 2500 nM
For compound 4 the middle estimate is 1.4-fold (0.15 log units) above the measured one; low and high end bracket the measured number.
By their numbers in this assay, from the lowest: compounds 3, 4, 2 and 1 (each within the scatter of the next).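

Methoxy in place of phenyl on this aromatic carbon, para to a large group, swaps 6 heavy atoms and a ring for 2 heavy atoms and no ring, yet gives a 1.0-fold higher number from compound 3 to compound 4 (0.02 log units; within the scatter) in this assay. So this position accepts a much smaller group here without a change beyond the scatter. The other two steps, a 1.0-fold lower number from compound 2 to compound 4 (0.02 log units; within the scatter) and a 1.8-fold lower number from compound 1 to compound 4 (0.25 log units; within the scatter), also stay within the scatter. No measurement here offers a reason for this result. From the compounds shown here alone, whether an amine or a carboxylic acid on this aromatic carbon, or a longer chain in the linker, would move the number beyond the scatter stays open.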